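The source may hold more compounds than are shown below. What is called first, only, known or untested is meant among the compounds shown, and "the series" means these compounds.

Measured in an ADME assay on MRC5 cells (Homo sapiens) for cytotoxicity, read by neutral red uptake, with a stated time of 24 h; on this read-out higher numbers stand for weaker inhibition and lower numbers for stronger inhibition:

- Compound 1 `CC(C)C(=O)Oc1c(C(C)C)cc2c3c1OC(=O)[C@@]31CCCC(C)(C)[C@@H]1CC2`: 119000 nM
- Compound 2 `CCCCCCCCCCCCCCCC(=O)Oc1c(C(C)C)cc2c3c1OC(=O)[C@@]31CCCC(C)(C)[C@@H]1CC2`: > 1000000 nM

For compound 2, the entry > 1000000 nM is a limit of the assay and not a number. Compound 1, by contrast, gives a true reading of 119000 nM.

The next compound to be tested is compound 3 `CC(C)c1cc2c3c(c1OC(=O)CCCc1c[nH]c4ccccc14)OC(=O)[C@@]31CCCC(C)(C)[C@@H]1CC2`. It keeps the core of compound 2, and the change is 1H-indol-3-yl in place of dodecyl on a saturated chain carbon, three bonds along the chain from a carbonyl carbon.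

Among the compounds with values here, no measured pair differs in a single place, so the only guide is the reading of compound 1 at 119000 nM, and the forecast is loose. The expected change in this assay is towards stronger inhibition, with an estimated size of an at least 4.0-fold lower number from compound 2 to compound 3 (0.60 log units; beyond the scatter). The estimate for compound 3 is 250000 nM, with an expected range of 70000 nM to 900000 nM.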

Compound 3, half-maximal inhibitory concentration: 54500 nM
The estimate for compound 3 lay 4.6-fold (0.66 log units) above the measured number, and the stated range ends above it.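

In this assay, 1H-indol-3-yl in place of dodecyl on a saturated chain carbon, three bonds along the chain from a carbonyl carbon, gives an at least 18-fold lower number from compound 2 to compound 3 (1.26 log units; beyond the scatter). Compound 2 stands at a limit and not at a number, so the size of this step is only a bound: the limit of > 1000000 nM in this assay, at which 1 of the 3 values shown sits.

3-(1H-indol-3-yl)propyl in place of isopropyl on a carbonyl carbon gives a 2.2-fold lower number from compound 1 to compound 3 (0.34 log units; beyond the scatter), a modest step but beyond the usual scatter, so the group carried on this carbonyl carbon does move the reading.

As far as these compounds go, whether the change comes from 1H-indol-3-yl itself or simply from the loss of dodecyl stays open, and a phenyl ring on the same chain would help separate the two. Also open, from the compounds shown here alone, is how the reading responds to an amine or a carboxylic acid at the end of that chain.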